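A Chloro Group Added to Compound 1

The source may hold more compounds than are shown below. What is called first, only, known or untested is meant among the compounds shown, and "the series" means these compounds.

Among the measured compounds shown here, in a functional assay on A549 cells (Homo sapiens) for antiproliferative activity, read by sulforhodamine B assay, with a stated time of 48 h (on this read-out higher numbers stand for weaker inhibition of growth and lower numbers for stronger inhibition of growth), compound 1 (`O=C(/C=C/c1cccc(S(=O)(=O)c2ccc3ccccc3n2)c1)NO`) gives 270 nM as the lower of the two numbers measured so far. Compound 2 (`O=C(/C=C/c1ccc(S(=O)(=O)c2ccc3ccccc3n2)cc1)NO`) gives 880 nM in the same test, and this gap lies beyond the usual scatter. Compound 3 (`O=C(/C=C/c1cccc(S(=O)(=O)c2ccc3cc(Cl)ccc3n2)c1)NO`) follows from compound 1 by one change, chloro in place of hydrogen on an aromatic carbon of a six-membered aromatic ring of carbon only. For the measured compounds named here, no measured pair shows this change, so the expectation in this assay rests on compound 1 at 270 nM alone. The expected move (a 1.1-fold lower number from compound 1 to compound 3 (0.03 log units; within the scatter)) is small, with no step beyond the scatter and no firm direction anticipated. For compound 3 the estimated value is 250 nM with an expected range from 90 nM to 700 nM in this test.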

Compound 3, concentration for 50% growth inhibition: 1010 nM
For compound 3 the middle estimate is 4.0-fold (0.61 log units) below the measured one, and the stated range ends below it.
By their numbers in this assay, from the lowest: compound 1; then compounds 2 and 3 (each within the scatter of the next).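

In this assay, chloro in place of hydrogen on this aromatic carbon, in the six-membered aromatic ring of carbon only within the fused system of two rings, gives a 3.7-fold higher number from compound 1 to compound 3 (0.57 log units; beyond the scatter). Among the compounds shown here, this position therefore responds to the change, with one chlorine atom enough to weaken inhibition of growth beyond the scatter, whereas the earlier compounds carried only hydrogen on this ring and gave no reading of it. No measurement shown here accounts for this step.

As far as these compounds go, whether the step belongs to chloro itself or would also follow from another group on this carbon, such as fluoro, methoxy or an amine, stays open. Also open, from the compounds shown here alone, is how chloro would behave on the other carbons of this ring.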